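Series notes: methyl position on the aryl of compound 1

The compounds below may be only part of what the source reports. "The series", "measured", "known", "first", "only" and "open" are said of these compounds alone.

Compound 1 `CC(=O)N1N=C(c2ccc(C)cc2)OC1c1ccc(Cl)c(Cl)c1` gives 19.4 nM in an assay on BTI cells for inhibition of Amine oxidase [flavin-containing] B (Homo sapiens), read by fluorescence and Amplex Red, with a stated time of 15 min (a higher number here means a weaker inhibitor, a lower number a stronger inhibitor), the highest of the three numbers recorded so far. Compound 2 `CC(=O)N1N=C(c2ccc([N+](=O)[O-])cc2)OC1c1ccc(Cl)c(Cl)c1` gives 9.46 nM in this assay; the step of a 2.1-fold lower number from compound 1 to compound 2 (0.31 log units; beyond the scatter) is the only move beyond the scatter that the set shows. Compound 3 `CC(=O)N1N=C(c2ccc([N+](=O)[O-])cc2)O[C@@H]1c1ccc(Cl)c(Cl)c1` gives 7.61 nM in this assay, and the step of a 1.2-fold lower number from compound 2 to compound 3 (0.09 log units; within the scatter) stays within the scatter; these two differ only in the fact that one of compounds 2 and 3 is drawn with a defined configuration and the other without, at the place where they differ.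

Compound 4 `CC(=O)N1N=C(c2ccccc2C)OC1c1ccc(Cl)c(Cl)c1` is not yet measured. It differs from compound 1 in that (2-methylphenyl in place of 4-methylphenyl on a carbon with a double bond to nitrogen). Within the data shown here, neither measured step exchanges 4-methylphenyl for 2-methylphenyl: the one beyond the scatter swaps the methyl for nitro, the other concerns only the drawn configuration. Among the measured compounds shown here, no step in this assay is therefore expected beyond the scatter in either direction. For compound 4 the estimate is 25 nM, with a range of 8 nM to 80 nM. The expected step of a 1.3-fold higher number from compound 1 to compound 4 (0.11 log units; within the scatter) is accordingly one that is estimated to remain within the usual scatter.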

Compound 4, half-maximal inhibitory concentration: 2460 nM
Compound 4: middle estimate off by 98-fold (1.99 log units), on the low side; the whole stated range lies below it.
By their numbers in this assay, from the lowest: compounds 3 and 2 (each within the scatter of the next); then compound 1; then compound 4.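

In this assay the place of the methyl on the aryl proves decisive: 2-methylphenyl in place of 4-methylphenyl gives a 130-fold higher number from compound 1 to compound 4 (2.10 log units; beyond the scatter), although the entering and leaving groups match in every count given. Among these compounds, this step is far larger than a 2.1-fold lower number from compound 1 to compound 2 (0.31 log units; beyond the scatter), so the one exchange of group seen earlier gave no sign of how much this aryl can depend on where its methyl sits. No measured properties of these groups are available. Among the compounds shown here, the one available observation, on drawn configuration in another pair, has no bearing on this step.

As far as these compounds go, whether an amine or a longer chain in place of the methyl of compound 4 would give a similar number remains open. From the compounds shown here alone, compound 4 is drawn without a configuration, and how its separate forms would read also remains open.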